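A few compounds are considered here, and "the series" means these few. Any claim that something is new, unique, unknown or untested is made for them only; others in the source may bear on it.

Compound 1, `O=C1N/C(=C\c2ccc(Cl)cc2)C(=O)N1c1ccc(Cl)cc1`: 35600 nM
Compound 2, `COc1ccc(N2C(=O)N/C(=C\c3ccc(O)cc3)C2=O)cc1`: > 200000 nM
Compound 3, `COc1cccc(N2C(=O)N/C(=C\c3ccc(O)cc3)C2=O)c1`: > 200000 nM

All three share one core and were tested in a functional assay on NCI-H292 cells (Homo sapiens) for antiproliferative activity; on this read-out higher numbers stand for weaker inhibition and lower numbers for stronger inhibition. For compound 3 the reading is a limit of the assay and not a number, > 200000 nM. Compound 2 likewise gives only a limit, > 200000 nM. Indeed (the limit of > 200000 nM in this assay, at which 2 of the 3 values shown sit). Compound 1 alone gives an actual number, 35600 nM. The next compound, compound 4, `O=C1N/C(=C\c2ccc(O)cc2)C(=O)N1c1cccc(Br)c1`, differs from compound 3 by bromo in place of methoxy on an aromatic carbon. Within the data shown here, no step between two measured compounds matches this change, so the expectation is loose. The expected step from compound 3 to compound 4 is an at least 1.3-fold lower number from compound 3 to compound 4 (0.12 log units; that floor lies within the scatter), toward somewhat stronger inhibition. Compound 4 is estimated at 150000 nM, between 40000 nM and 400000 nM.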

Compound 4, half-maximal inhibitory concentration: > 200000 nM
Compound 4: a limit, no number; the forecaster's own chance of this, stated with the estimate: 50%; middle value at least 1.3-fold (0.12 log units) from the limit.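

In this assay compound 3 and compound 4 both give only a limit and not a number, so no step can be read between them. The compounds shown leave open whether bromo in place of methoxy on an aromatic carbon changes inhibition at all.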